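This account rests on a few compounds, and the source may have more. Where it says the series, first, only, none or still open, it means among the compounds named here.

Measured so far:
compound 1 `COc1cc(COc2ccc(-c3cc(CN4CCN(Cc5ccc(C(F)(F)F)cc5)CC4)no3)cc2)cc(OC)c1`: 100 nM
compound 2 `COc1cc(COc2ccc(-c3cc(CN4CCN(Cc5ccc(C(F)(F)F)cc5)CC4)no3)cc2)cc(OC)c1OC`: 1800 nM
compound 3 `N#Cc1cccc(COc2ccc(-c3cc(CN4CCN(c5ccc(F)cc5)CC4)no3)cc2)c1`: 2400 nM

In a functional assay on MCF7 cells (Homo sapiens) for antiproliferative activity, read by sulforhodamine B assay, with a stated time of 72 h (on this read-out lower numbers stand for stronger inhibition and higher numbers for weaker inhibition), compound 3 gives the highest of the three numbers; compound 2 lies within the scatter of it, while compound 1 sits far lower. Compound 4 `N#Cc1cccc(COc2ccc(-c3cc(CN4CCN(C(=O)C5CCCO5)CC4)no3)cc2)c1` differs from compound 3 by (oxolan-2-yl)carbonyl in place of 4-fluorophenyl on an amine nitrogen in a ring. Among the compounds with values here, the only measured step, an 18-fold higher number from compound 1 to compound 2 (1.26 log units; beyond the scatter), concerns a methoxy on an aromatic carbon and does not touch the ring nitrogen, so no measured step bears on this change. The expected step is estimated as a 1.3-fold higher number from compound 3 to compound 4 (0.10 log units; within the scatter), a change that is expected to stay within the scatter, though with wide uncertainty. Compound 4 is estimated at 3000 nM, between 800 nM and 12000 nM.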

Compound 4, half-maximal inhibitory concentration: 3800 nM
For compound 4 the middle estimate is 1.3-fold (0.10 log units) below the measured one; the range from low to high includes it.
By their numbers in this assay, from the lowest: compound 1; then compounds 2, 3 and 4 (each within the scatter of the next, the first and the last beyond it).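

In this assay, (oxolan-2-yl)carbonyl in place of 4-fluorophenyl on the amine nitrogen in the ring gives a 1.6-fold higher number from compound 3 to compound 4 (0.20 log units; within the scatter), so this exchange of an aromatic ring for a carbonyl-linked non-aromatic ring leaves the number within the scatter. It is the only step shown at this nitrogen, since the earlier step concerned a methoxy on an aromatic carbon. No evidence is available to explain this result. From the compounds shown here alone, whether an amine or a carboxylic acid on this nitrogen would move the number beyond the scatter stays open.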